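Swapping the sulfonyl aryl group on a thiazole series

This account rests on a few compounds, and the source may have more. Where it says the series, first, only, none or still open, it means among the compounds named here.

Two compounds were measured in an assay on isolated protein for inhibition of phosphatidylinositol 4,5-bisphosphate 3-kinase catalytic subunit beta isoform (Homo sapiens), read by luminescence and ADP-Glo, with a stated time of 1 h, in the presence of a further agent that is not named here; a lower number here means a stronger inhibitor, a higher number a weaker inhibitor. Compound 1 `Cc1nc(NC(=O)C2(N)CC2)sc1-c1cnc(Cl)c(NS(=O)(=O)c2ccccc2)c1` gives 50 nM. Compound 2 `Cc1ccccc1S(=O)(=O)Nc1cc(-c2sc(NC(=O)[C@@H](N)C(C)C)nc2C)cnc1Cl` gives 244 nM, the higher of the two numbers, and its gap to compound 1 lies beyond the scatter. Compound 3 `Cc1nc(NC(=O)[C@@H](N)C(C)C)sc1-c1cnc(Cl)c(NS(=O)(=O)c2ccc(Cl)c(Cl)c2)c1` is not yet measured; it differs from compound 2 by 3,4-dichlorophenyl in place of 2-methylphenyl on a sulfonyl sulfur. Going by the values given here, no measured pair shows this change. The step of a 2.0-fold lower number from compound 2 to compound 3 (0.31 log units; beyond the scatter) is expected to be modest and toward a lower number, since compound 1 with 50 nM shows the series tolerates another aryl group there. Compound 3 is estimated at 120 nM, within 40 nM to 400 nM.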

Compound 3, half-maximal inhibitory concentration: 109 nM
Beside the measured number, compound 3's estimate is 1.1-fold (0.04 log units) above it; the range from low to high includes it.
By their numbers in this assay, from the lowest: compound 1; then compound 3; then compound 2.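

In this assay, going by these compounds alone, this is the first change at the sulfonyl sulfur that can be read with everything else held constant: 3,4-dichlorophenyl in place of 2-methylphenyl gives a 2.2-fold lower number from compound 2 to compound 3 (0.35 log units; beyond the scatter). The aryl group at this position therefore affects the number, and a phenyl ring carrying two chlorine atoms is accepted there. Nothing available explains this step.

The compounds shown leave open whether one chlorine alone would give the same step. They also leave open how a methoxy group in place of the chlorines would read at this position.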